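Benzylamino to dimethylamino: expected effect on cell tolerance

This account rests on a few compounds, and the source may have more. Where it says the series, first, only, none or still open, it means among the compounds named here.

Measured compounds:
Compound 1, `Cc1cc(C)cc(Cn2c(=O)cc(N)n(CC#N)c2=O)c1`, in an ADME assay on MT4 cells (Homo sapiens) for cytotoxicity, read by MTT assay, with a stated time of 4 days; a lower number here means that less compound is tolerated, a higher number that more compound is tolerated: > 100000 nM, a limit of the assay.
Compound 2, `Cc1cc(C)cc(Cn2c(=O)cc(NCc3ccccc3)n(Cc3ccccc3)c2=O)c1`: > 100000 nM, a limit of the assay.
Compound 3, `Cc1cc(C)cc(Cn2c(=O)cc(N)n(Cc3ccncc3)c2=O)c1`: > 100000 nM, a limit of the assay.

All three measured compounds share the same core and differ only in the groups hung on it. None of them gave a number in this assay; each result is a limit, meaning the cells tolerated the compound up to the highest concentration tested. Compound 2 therefore stands at that limit, and the two other values shown are limits as well (the limit of > 100000 nM in this assay, at which 3 of the 3 values shown sit). Among the compounds with values here, the only measured pair that differs in one place is compound 1 and compound 3, where a step that the two limits leave unreadable from compound 1 to compound 3; the two limits leave that step unreadable.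

Compound 4, `Cc1cc(C)cc(Cn2c(=O)cc(N(C)C)n(Cc3ccccc3)c2=O)c1`, has not yet been measured. It differs from compound 2 in one place: dimethylamino in place of benzylamino on an aromatic carbon. Within the data shown here, no measured step bears directly on this change, and the two limits on either side of the one measured step give no size at all.

With every shown value sitting at the same limit (the limit of > 100000 nM in this assay, at which 3 of the 3 values shown sit), the most reasonable expectation for compound 4 is another limit rather than a readable number. Compound 4 is thus estimated at 150000 nM, with a range from 70000 nM to 400000 nM. The expected step that the limit leaves unreadable from compound 2 to compound 4 is no step beyond the scatter, and the measurement will most likely again report only a limit.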

Compound 4, half-maximal cytotoxic concentration: 48000 nM
The estimate for compound 4 lay 3.1-fold (0.49 log units) above the measured number, and the stated range ends above it.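

In this assay, compound 4 is the only compound shown that gives a readable number, and putting dimethylamino in place of benzylamino on this aromatic carbon, ortho to a benzyl group, gives an at least 2.0-fold lower number from compound 2 to compound 4 (0.31 log units; beyond the scatter). The value of compound 2, > 100000 nM, is a limit of the assay. The group on this carbon can therefore shift the result in this assay, which the earlier compounds could not show, since compound 4 is the one value shown that stands off this limit: the limit of > 100000 nM in this assay, at which 3 of the 4 values shown sit.

The change takes away a six-membered aromatic ring and a hydrogen-bond donor together, and it also shortens the group from 8 heavy atoms to 3, so the compounds shown cannot say which of these differences goes with the lower number. A methylamino group on the same carbon, which keeps the amine hydrogen but has no ring, or a longer chain such as diethylamino, would help to pull these differences apart.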